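Cyclic amidine in place of aminopyrimidine on the chroman series

The compounds below may be only part of what the source reports. "The series", "measured", "known", "first", "only" and "open" are said of these compounds alone.

Measured so far:
compound 1 `c1cnc(NCCNCC2CCc3ccccc3O2)nc1` — 31.6 nM
compound 2 `COc1cccc2c1OC(CNCCCNC1=NCCCN1)CC2` — 0.794 nM
compound 3 `c1ccc2c(c1)CCCC(CNCCCNC1=NCCCN1)O2` — > 1000 nM

In an assay on isolated protein (Bos taurus) with 5-hydroxytryptamine receptor 1D (Homo sapiens) as the target (a lower number here means a stronger inhibitor, a higher number a weaker inhibitor), compound 1 gives 31.6 nM, the highest of the two numerical values; compound 2 sits at 0.794 nM, a gap beyond the scatter. For compound 3 the result is a limit of the assay, > 1000 nM, so it is one of the values that sit at the limit (the limit of > 1000 nM in this assay, at which 1 of the 3 values shown sits).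

Compound 4 `c1ccc2c(c1)CCC(CNCCCNC1=NCCN1)O2` is not yet measured. It differs from compound 1 by a group of 7 heavy atoms (4 carbon, 3 nitrogen; one five-membered non-aromatic ring with 2 hetero atoms) in place of a group of 7 heavy atoms (4 carbon, 3 nitrogen; one six-membered aromatic ring with 2 hetero atoms), on a saturated chain carbon, two bonds along the chain from an amine nitrogen. Going by the values given here, no measured pair isolates this change, so only what the two numbers of compound 1 and compound 2 show is available: the cyclic amidine of compound 2 goes with the lowest number of the set, though compound 2 also carries a methoxy group and cannot serve as a clean comparison.

The step in this assay is expected to go toward a lower number, beyond the scatter, as a 7.9-fold lower number from compound 1 to compound 4 (0.90 log units; beyond the scatter). For compound 4 the estimate is 4 nM, with a range of 0.6 nM to 25 nM.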

Compound 4, half-maximal inhibitory concentration: 6.31 nM
Compound 4: middle estimate off by 1.6-fold (0.20 log units), on the low side; the measured number falls inside the stated range.
By their numbers in this assay, from the lowest: compound 2; then compound 4; then compound 1. At a limit, above all of these: compound 3.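

In this assay, going by these compounds alone, this is the first pair that isolates the group on the chain: with the core of compound 1 kept, replacing (pyrimidin-2-yl)amino with the five-membered non-aromatic ring group gives a 5.0-fold lower number from compound 1 to compound 4 (0.70 log units; beyond the scatter). The place on a saturated chain carbon, two bonds along the chain from an amine nitrogen, therefore accepts a non-aromatic ring group in place of the aromatic one, and compound 4 reaches its number without a methoxy group. Nothing measured here bears on the cause of this step.

No pair shown isolates the methoxy group or the ring size of the cyclic amidine. An open-chain guanidine or a primary amine at this place would show how much of the step depends on the ring.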